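The source may hold more compounds than are shown below. What is called first, only, known or untested is meant among the compounds shown, and "the series" means these compounds.

Measured in a functional assay on PC-3 cells (Homo sapiens) for antiproliferative activity, read by MTT assay, with a stated time of 72 h (on this read-out lower numbers stand for stronger inhibition and higher numbers for weaker inhibition), so far
compound 1 `COc1cc(/C=C/C(=O)/C=C(O)/C=C/c2ccc(OC(=O)C(C)(CO)CO)c(OC)c2)ccc1OC(=O)C(C)(CO)CO` gives 3900 nM
compound 2 `CC(CO)(CO)C(=O)Oc1ccc(/C=C/C(=O)/C=C(O)/C=C/c2ccc(OC(=O)C(C)(CO)CO)cc2)cc1` gives 5590 nM
compound 3 `CCC(CO)(CO)C(=O)Oc1cc(/C=C/C(=O)/C=C(O)/C=C/c2ccc(OC)c(O)c2)ccc1OC` gives 7030 nM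

Compound 1 stands level with compound 2 and compound 3, all three values lying within the scatter of one another. Compound 4 `COc1ccc(/C=C/C(O)=C/C(=O)/C=C/c2ccc(OC(=O)C(C)(CO)CO)c(OC)c2)cc1OC` differs from compound 1 in one place: methyl in place of (1,1-bis(hydroxymethyl)ethyl)carbonyl on an oxygen on an aromatic ring with methyl in place of (1,1-bis(hydroxymethyl)ethyl)carbonyl on an oxygen on an aromatic ring. Within the data shown here, no measured pair isolates this change. Compound 3, at 7030 nM with a single ester, is the nearest guide, so no step beyond the scatter is expected in this assay in either direction. The expected 1.4-fold higher number from compound 1 to compound 4 (0.15 log units; within the scatter) is small. For compound 4 the estimate is 5500 nM with an expected range from 2000 nM to 15000 nM as its upper end.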

Compound 4, half-maximal inhibitory concentration: 7640 nM
Estimate against measurement, compound 4: 1.4-fold (0.14 log units) below; the range from low to high includes it.
By their numbers in this assay, from the lowest: compounds 1, 2, 3 and 4 (each within the scatter of the next).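

In this assay, among these compounds, methyl in place of (1,1-bis(hydroxymethyl)ethyl)carbonyl on an oxygen on an aromatic ring gives a 2.0-fold higher number from compound 1 to compound 4 (0.29 log units; within the scatter), the first reading of this change in a matched pair. At this position, the ester is thus not shown to matter in this assay, despite the loss of its hydroxymethyl arms. No measurement at hand bears on the cause of this reading.

Open, as far as these compounds go, is whether a longer chain, an amine or a carboxylic acid on this oxygen would give a step beyond the scatter.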